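Chloro for methyl repeated on a second core

The source may report more compounds than this note shows. Statements on the series, on what has been measured and on what is new or still open speak of the compounds shown alone.

Compound 1 `Cc1nc(-c2cccc(Cl)c2)sc1COc1ccc(S(=O)(=O)CC(=O)O)cc1` and compound 2 `Cc1cccc(-c2nc(C)c(COc3ccc(S(=O)(=O)CC(=O)O)cc3)s2)c1` share one core. In a functional assay on CHO cells for agonist activity at Free fatty acid receptor 1 (Homo sapiens), read by FLIPR and calcium flux (a lower number here means that less compound is needed, a higher number that more compound is needed for the effect), compound 2 gives 214 nM and compound 1 gives 251 nM. The difference between them, (chloro in place of methyl on an aromatic carbon), made a step of a 1.2-fold higher number from compound 2 to compound 1 (0.07 log units; within the scatter). Compound 3 `Cc1ccc(-c2c(C)noc2C)cc1COc1ccc(S(=O)(=O)CC(=O)O)cc1` is built on another core; the difference between the two cores is not broken down here. In this assay compound 3 gives 427 nM. Compound 4 `Cc1noc(C)c1-c1ccc(Cl)c(COc2ccc(S(=O)(=O)CC(=O)O)cc2)c1` carries the same kind of change on the core of compound 3, (chloro in place of methyl on an aromatic carbon); here the place is ortho to a large group and para to a 3,5-dimethyl-1,2-oxazol-4-yl group, whereas in compound 1 it is meta to a large group, so the surroundings differ. The step of a 1.1-fold higher number from compound 3 to compound 4 (0.04 log units; within the scatter) is expected to stay small, resting on the earlier step of a 1.2-fold higher number from compound 2 to compound 1 (0.07 log units; within the scatter) from the same kind of change. Compound 4 is estimated at 470 nM, with a likely range from 220 nM to 1000 nM.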

Compound 4, half-maximal effective concentration: 234 nM
For compound 4 the middle estimate is 2.0-fold (0.30 log units) above the measured one, within the range that was stated.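

In this assay, chloro in place of methyl on the second core gives a 1.8-fold lower number from compound 3 to compound 4 (0.26 log units; within the scatter), so on this core too the step stays within the scatter. Set beside the step on the first core, it does not differ beyond what two such steps can show: the same change on two cores in this assay, a 1.2-fold higher number (0.07 log units; within the scatter) from compound 2 to compound 1 and a 1.8-fold lower number (0.26 log units; within the scatter) from compound 3 to compound 4, 2.1-fold (0.33 log units) apart, within the scatter of two such steps

Across these two cores the exchange can therefore be carried over without a step beyond the scatter, but two pairs do not show that this holds on further cores, nor do they separate any effect of the differing surroundings of the changed place.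

The compounds shown leave open how fluoro, methoxy or nitrile at the same place would read in this assay.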